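This account rests on a few compounds, and the source may have more. Where it says the series, first, only, none or still open, it means among the compounds named here.

Working notes on a small set built around one shared core. Compound 1 is `CC1CCN(c2ccc(Nc3ncc4c(n3)N(C3CCCC3)CC(=O)N4)cc2)CC1`, compound 2 is `CN1CCN(c2ccc(Nc3ncc4c(n3)N(C3CCCC3)CC(=O)N4)nc2)CC1`, compound 3 is `CC1CCN(c2ccc(Nc3ncc4c(n3)N(C3CCCC3)CC(=O)N4C)cc2)CC1`, and compound 4, not yet measured, is `CN1CCN(c2ccc(Nc3ncc4c(n3)N(C3CCCC3)CC(=O)N4C)nc2)CC1`. All are read in a functional assay on MDA-MB-231 cells (Homo sapiens) for inhibition, read by MTT assay, with a stated time of 48 h; a higher number here means a weaker inhibitor, a lower number a stronger inhibitor.

In this assay compound 1 gives 22700 nM. Compound 2 returns only a limit of the measurement in this assay, > 30000 nM. Compound 3 likewise returns only a limit in this assay, > 30000 nM. The change from compound 1 to compound 3 is methyl in place of hydrogen on an amide-type nitrogen in a ring and produced an at least 1.3-fold higher number from compound 1 to compound 3 (0.12 log units; that floor lies within the scatter); the true size of that step cannot be read because of the limit of > 30000 nM in this assay, at which 2 of the 3 values shown sit.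

Compound 4 stands to compound 2 as compound 3 stands to compound 1: methyl in place of hydrogen on an amide-type nitrogen in a ring. The place lines of the two changes agree word for word, so this is the same change made on a second core. How the core of compound 2 differs from the core of compound 1 is not broken down here.

For the step from compound 2 to compound 4 in this assay the expectation is a step that the limit leaves unreadable from compound 2 to compound 4, set beside the earlier step and resting on compound 2 already reaching a limit and on the weakening seen in an at least 1.3-fold higher number from compound 1 to compound 3 (0.12 log units; that floor lies within the scatter). Compound 4 is therefore expected to return a limit as well, with an estimate of 60000 nM and a range from 30000 nM to 200000 nM.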

Compound 4, half-maximal inhibitory concentration: 23700 nM
For compound 4 the middle estimate is 2.5-fold (0.40 log units) above the measured one; measured number outside the range, below it.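

Carried to the core of compound 2, methyl in place of hydrogen on an amide-type nitrogen in a ring gives an at least 1.2-fold lower number from compound 2 to compound 4 (0.10 log units; that floor lies within the scatter) in this assay, with compound 4 at 23700 nM. The printed floors of the two steps point in opposite directions, yet each lies within the scatter, so this is no evidence that the change acts differently on the two cores, and the true size of neither step can be read: the same change on two cores in this assay, an at least 1.3-fold higher number (0.12 log units; that floor lies within the scatter) from compound 1 to compound 3 and an at least 1.2-fold lower number (0.10 log units; that floor lies within the scatter) from compound 2 to compound 4; the limit leaves it open whether they differ
The set therefore shows that a methyl on this nitrogen is compatible with a measurable value on the core of compound 2, but it does not show that the effect of the change carries over from one core to the other, or that it fails to do so: the limit of > 30000 nM in this assay, at which 2 of the 4 values shown sit.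

On these data alone, the true values of compound 2 and compound 3 remain open, since each is known only as a limit of the assay, and with them the real size of both steps. Also open, as far as these compounds go, is how this series would respond if the amide hydrogen were replaced by something other than methyl, such as an ethyl group, a longer chain or a chain ending in an amine or a carboxylic acid.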